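The compounds below may be only part of what the source reports. "The series", "measured", "known", "first", "only" and "open" are said of these compounds alone.

Compound 1 `C[C@]1(CN2CCc3nc(C(F)(F)F)ccc3C2)Cn2cc([N+](=O)[O-])nc2O1`: "not determined" (no result reported)
Compound 2 `C[C@]1(CN2CCc3nc(-c4ccc(C(F)(F)F)cc4)ccc3C2)Cn2cc([N+](=O)[O-])nc2O1`: > 32 ug/mL
Compound 3 `C[C@]1(CN2CCc3nc(-c4ccc(F)c(F)c4)ccc3C2)Cn2cc([N+](=O)[O-])nc2O1`: > 32 ug/mL

In an ADME assay on Vero cells (Chlorocebus sabaeus) for cytotoxicity, read by MTT assay, with a stated time of 72 h (a lower number here means that less compound is tolerated, a higher number that more compound is tolerated), compound 3 gives > 32 ug/mL, which is a limit and not a number. Compound 2 gives > 32 ug/mL, also a limit. All there is to compare is the limit of > 32 ug/mL in this assay, at which 2 of the 3 values shown sit.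

Compound 4 `C[C@]1(CN2CCc3nc(-c4cccc(F)c4F)ccc3C2)Cn2cc([N+](=O)[O-])nc2O1` has 2,3-difluorophenyl in place of 3,4-difluorophenyl on an aromatic carbon, the same atoms joined differently: 2,3-difluorophenyl in place of 3,4-difluorophenyl on an aromatic carbon.

Going by the values given here, the one measured step, a step that the two limits leave unreadable from compound 2 to compound 3, has no readable size, so it points to no change in this assay. No shift beyond the scatter is expected, and the estimated step is a step that the limit leaves unreadable from compound 3 to compound 4. For compound 4 the estimate is 40 ug/mL, with an expected range from 20 ug/mL to 80 ug/mL.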

Compound 4, half-maximal cytotoxic concentration: > 32 ug/mL
Compound 4: no number, only a limit; the forecaster's own chance of this, stated with the estimate: 85%; the middle value does not contradict the limit.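

Compound 4 gives only a limit in this assay, so its steps from compound 2 and from compound 3 cannot be read. Still open, on these data alone, is whether swapping these phenyl groups changes cell tolerance at all.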